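Working notes: compound 3 to compound 4 in one series

This account rests on a few compounds, and the source may have more. Where it says the series, first, only, none or still open, it means among the compounds named here.

Measured so far:
Compound 1 `CC(C)c1c(C(=O)N(C)Cc2ccccc2)nn(-c2ccc(F)cc2)c1CC[C@@H](O)C[C@@H](O)CC(=O)O`: 6.2 nM
Compound 2 `CC(C)c1c(C(=O)N(C)Cc2cccc(F)c2)nn(-c2ccc(F)cc2)c1CC[C@@H](O)C[C@@H](O)CC(=O)O`: 4.1 nM
Compound 3 `Cc1ccc(CN(C)C(=O)c2nn(-c3ccc(F)cc3)c(OC[C@@H](O)C[C@@H](O)CC(=O)O)c2C(C)C)cc1`: 37 nM

All three have been run in an assay on microsomes from liver for inhibition of 3-hydroxy-3-methylglutaryl-coenzyme A reductase (Rattus norvegicus); a higher number here means a weaker inhibitor, a lower number a stronger inhibitor. Compound 3 gives the highest number of the three; compound 1 and compound 2 both sit below it, each gap beyond the scatter. Compound 4 `COCc1cccc(CNC(=O)c2nn(-c3ccc(F)cc3)c(OC[C@@H](O)C[C@@H](O)CC(=O)O)c2C(C)C)c1` is compound 3 with (3-(methoxymethyl)benzyl)amino in place of methyl(4-methylbenzyl)amino on a carbonyl carbon. For the measured compounds named here, the only measured step, a 1.5-fold lower number from compound 1 to compound 2 (0.18 log units; within the scatter), is a change of a different kind on a different pair and lies within the scatter, so it gives no direct guide. Nothing measured here speaks to a change on the amide side. In this assay compound 4 is therefore expected close to compound 3, with a step of a 1.1-fold higher number from compound 3 to compound 4 (0.03 log units; within the scatter) and no shift expected beyond the scatter. The estimate for compound 4 is 40 nM, in the range 12 nM to 130 nM.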

Compound 4, half-maximal inhibitory concentration: 31 nM
Estimate against measurement, compound 4: 1.3-fold (0.11 log units) above, within the range that was stated.
By their numbers in this assay, from the lowest: compounds 2 and 1 (each within the scatter of the next); then compounds 4 and 3 (each within the scatter of the next).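

With (3-(methoxymethyl)benzyl)amino in place of methyl(4-methylbenzyl)amino on a carbonyl carbon, this assay gives a 1.2-fold lower number from compound 3 to compound 4 (0.08 log units; within the scatter) on this first read of the amide side. The entering group adds a hydrogen-bond donor and a hydrogen-bond acceptor, yet the step stays within the scatter, so this position accepts the change without a measurable shift. No evidence at hand bears on this result.

The contributions of the amide hydrogen and the methoxymethyl group remain unseparated. Also open, on these data alone, is whether a primary amine or a carboxylic acid in place of the methoxymethyl group would be accepted equally.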